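The source may hold more compounds than are shown below. What is called first, only, known or untested is meant among the compounds shown, and "the series" means these compounds.

Measured compounds in a functional assay on SK-BR-3 cells (Homo sapiens) for antiproliferative activity, read by MTT assay, with a stated time of 72 h; a higher number here means a weaker inhibitor, a lower number a stronger inhibitor:

Compound 1 `C=C(C)CCOC(=O)C[C@@H]1C(C(=O)OC)=CO[C@@H](O[C@@H]2O[C@H](CO)[C@@H](O)[C@H](O)[C@H]2O)/C1=C/C` gives > 15000 nM, which is a limit of the assay.
Compound 2 `C/C=C1/[C@H](O[C@@H]2O[C@H](COC(C)=O)[C@@H](OC(C)=O)[C@H](OC(C)=O)[C@H]2OC(C)=O)OC=C(C(=O)OC)[C@H]1CC(=O)OCCC1CCCCC1` gives > 15000 nM, again a limit.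
Compound 3 `C=C(C)CCOC(=O)C[C@@H]1C(C(=O)OC)=CO[C@@H](O[C@@H]2O[C@H](COC(C)=O)[C@@H](OC(C)=O)[C@H](OC(C)=O)[C@H]2OC(C)=O)/C1=C/C` gives > 15000 nM, also a limit.

Compound 1 therefore stands at the limit, and so do the two other measured compounds: all three share (the limit of > 15000 nM in this assay, at which 3 of the 3 values shown sit). No measured number separates them, so none can be called stronger or weaker than another.

The compound to be estimated is compound 4 `C/C=C1/[C@H](O[C@@H]2O[C@H](CO)[C@@H](O)[C@H](O)[C@H]2O)OC=C(C(=O)OC)[C@H]1CC(=O)OCCCc1ccc(OC)c(OC)c1`. Compared with compound 1 it carries 3,4-dimethoxybenzyl in place of 1-methylethenyl on a saturated chain carbon, two bonds along the chain from an oxygen next to a carbonyl group. For the measured compounds named here, the only measured step that touches the same place is a step that the two limits leave unreadable from compound 2 to compound 3. Both of its ends are limits, and its size cannot be read. Nothing measured here shows how a change at this position moves the read-out, in either direction.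

With every measured value sitting at the limit, the expectation for compound 4 can only rest on that limit. Compound 4 is expected to give 20000 nM, with a range from 5000 nM to 60000 nM. The expected step that the limit leaves unreadable from compound 1 to compound 4 is thus taken to be no movement beyond the scatter, and the most likely outcome is that the assay again reports only a limit.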

Compound 4, half-maximal inhibitory concentration: > 20000 nM
Compound 4 gave a limit, no number (the forecaster's own chance of this, stated with the estimate: 75%); the middle value lies on the limit itself.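

In this assay compound 4 gives > 20000 nM, which is a limit of the assay and not a number. Compound 1 also stands only at a limit, so the step between compound 1 and compound 4 cannot be read. The compounds shown leave open whether any group at this place on the chain gives a measurable value in this assay.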